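The source may hold more compounds than are shown below. What is called first, only, known or untested is meant among the compounds shown, and "the series" means these compounds.

Working notes on the series. In an ADME assay on BJ cells (Homo sapiens), read by MTT assay, with a stated time of 72 h (a higher number here means a weaker inhibitor, a lower number a stronger inhibitor), compound 1 `Nc1nc(N)c2c(-c3ccsc3)cn([C@@H]3O[C@H](CO)[C@@H](O)[C@H]3O)c2n1` gives > 100000 nM as a limit of the assay and not a number. Compound 2 `Cc1nc(N)c2c(-c3ccoc3)cn([C@@H]3O[C@H](CO)[C@@H](O)[C@H]3O)c2n1` gives > 100000 nM in this assay and this too is a limit and not a number. Compound 2 therefore has no numeric position, and the record so far reads the limit of > 100000 nM in this assay, at which 2 of the 2 values shown sit, with no number for either compound.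

Compound 3 `Cc1nc(N)c2c(-c3ccsc3)cn([C@@H]3O[C@H](CO)[C@@H](O)[C@H]3O)c2n1` comes from compound 2 by a single swap, thiophen-3-yl in place of furan-3-yl on an aromatic carbon, counted as thiophen-3-yl in place of furan-3-yl on an aromatic carbon with the rest of the structure unchanged.

For the measured compounds named here, no measured step sizes this swap. The expectation in this assay is no change beyond the scatter, with no direction favoured, and a further limit is the likeliest report. The estimated a number no higher from compound 2 to compound 3 (the limit leaves the size open) is nominal, as it is set against a limit. For compound 3 the estimated value is 100000 nM with an expected range from 40000 nM to 200000 nM as its upper end.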

Compound 3, half-maximal inhibitory concentration: > 100000 nM
Compound 3: no number, only a limit (the forecaster's own chance of this, stated with the estimate: 80%); the middle value lies on the limit itself.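

In this assay compound 3 gives a limit and not a number, so its steps from compound 2 and from compound 1 cannot be read. The record stands at a single reading: the limit of > 100000 nM in this assay, at which 3 of the 3 values shown sit.

The compounds shown leave open whether thiophen-3-yl and furan-3-yl, or methyl and amino, differ at all in this assay.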